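Naphthalen-2-yl on the ring nitrogen: compound 4 expected

The compounds below may be only part of what the source reports. "The series", "measured", "known", "first", "only" and "open" are said of these compounds alone.

Measured so far in a functional assay, with a stated time of 20 min, tested at 2.5 mg/mL; a lower number here means a weaker effect, a higher number a stronger effect of the compound at the concentration tested:
Compound 1, `CC(C)[C@@H]1CC[C@@H](C)C[C@@]12N(C)C(=O)[C@@H]1[C@H]3C(=O)NC(=O)[C@H]3ON12`: 67.2%
Compound 2, `COc1ccc(N2C(=O)[C@H]3[C@H](ON4[C@@H]3C(=O)N(C)[C@@]43C[C@H](C)CC[C@H]3C(C)C)C2=O)cc1`: 65.3%
Compound 3, `Cc1cccc(N2C(=O)[C@H]3[C@H](ON4[C@@H]3C(=O)N(C)[C@@]43C[C@H](C)CC[C@H]3C(C)C)C2=O)c1`: 57.6%

On the numbers shown, compound 3 sits at the lower end of the three, yet the steps of a number 9.6 percentage points lower from compound 1 to compound 3 (within the scatter) and a number 7.7 percentage points lower from compound 2 to compound 3 (within the scatter) both lie within the usual scatter, so no order among compounds 1, 2 and 3 can be claimed from them. The change now considered is naphthalen-2-yl in place of 3-methylphenyl on an amide-type nitrogen in a ring, giving compound 4, `CC(C)[C@@H]1CC[C@@H](C)C[C@@]12N(C)C(=O)[C@@H]1[C@H]3C(=O)N(c4ccc5ccccc5c4)C(=O)[C@H]3ON12`. Among the compounds with values here, the steps that bear on it are those that varied the same ring nitrogen: a number 1.9 percentage points lower from compound 1 to compound 2 (within the scatter), a number 9.6 percentage points lower from compound 1 to compound 3 (within the scatter) and a number 7.7 percentage points lower from compound 2 to compound 3 (within the scatter), each within the scatter. Hydrogen, 4-methoxyphenyl and 3-methylphenyl at this position have thus all given numbers in this assay that cannot be told apart, and nothing in the three compounds suggests that a larger two-ring group would move the read-out. Compound 4 is therefore expected to show no step beyond the scatter, with a number 2.4 percentage points higher from compound 3 to compound 4 (within the scatter) as the estimated change. For compound 4 the estimate in this assay is 60%, with a range from 45% to 75%.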

Compound 4, a percentage reported as activity, at one concentration (the size of the read-out at that concentration, not a potency): 39.6%
Estimate against measurement, compound 4: 20.4 percentage points above, and the stated range ends above it.
By their numbers in this assay, from the lowest: compound 4; then compounds 3, 2 and 1 (each within the scatter of the next).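

In this assay, the amide-type nitrogen turns out to be a place where a change can move the read-out: naphthalen-2-yl in place of 3-methylphenyl gives a number 18 percentage points lower from compound 3 to compound 4 (beyond the scatter), while the same group gives a number 25.7 percentage points lower from compound 2 to compound 4 (beyond the scatter) in place of 4-methoxyphenyl and a number 27.6 percentage points lower from compound 1 to compound 4 (beyond the scatter) in place of hydrogen. Hydrogen and the two groups with one aromatic ring could not be told apart here, whereas the group with two six-membered aromatic rings stands beyond the scatter from all three, which makes compound 4 the lowest of the four in this assay. Nothing available accounts for this drop.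

The compounds shown do not settle whether the drop goes with the second aromatic ring as such or with the way it is attached, since naphthalen-1-yl and quinolin-2-yl are not among them. They also leave open how an aryl group carrying an amine or a carboxylic acid would read at this nitrogen, and whether the step would hold if the rest of the shared core were changed.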